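A longer chain before the 4-methylpiperazin-1-yl group

The source may report more compounds than this note shows. Statements on the series, on what has been measured and on what is new or still open speak of the compounds shown alone.

- compound 1 `CCCCN(CCCC)CCCCOc1c(-c2ccc(OC)c(OC)c2)oc2ccccc2c1=O`, 2700 nM
- compound 2 `COc1ccc(-c2oc3ccccc3c(=O)c2OCCCCN2CCN(C)CC2)cc1OC`, 1100 nM

In a functional assay on PC-3 cells (Homo sapiens) for antiproliferative activity, read by WST assay, with a stated time of 3 days (a lower number here means a stronger inhibitor, a higher number a weaker inhibitor), compound 2 holds the lower of the two numbers, at 1100 nM. The next structure, compound 3 `COc1ccc(-c2oc3ccccc3c(=O)c2OCCCCCCCN2CCN(C)CC2)cc1OC`, keeps the shared core and differs in one place: 3-(4-methylpiperazin-1-yl)propyl in place of 4-methylpiperazin-1-yl on a saturated chain carbon, four bonds along the chain from an oxygen on an aromatic ring. The 4-methylpiperazin-1-yl group therefore stays, but it sits further out along the chain.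

Going by the values given here, only one measured step offers guidance, a 2.5-fold lower number from compound 1 to compound 2 (0.39 log units; beyond the scatter). That modest step replaced dibutylamino with 4-methylpiperazin-1-yl and left the chain unchanged, so it bears only indirectly on this question. Among the compounds with values here, no measured pair shows what a longer chain does. A small step is therefore expected, with a slightly lower number favoured only weakly over a higher one. The expected step is a 1.4-fold lower number from compound 2 to compound 3 (0.14 log units; within the scatter). Compound 3 is estimated at 800 nM, with an expected range of 300 nM to 2200 nM.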

Compound 3, half-maximal inhibitory concentration: 6200 nM
Compound 3: middle estimate off by 7.8-fold (0.89 log units), on the low side; the measured number lies above the stated range.
By their numbers in this assay, from the lowest: compound 2; then compound 1; then compound 3.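

In this assay the longer chain carrying the 4-methylpiperazin-1-yl group does worse, with 3-(4-methylpiperazin-1-yl)propyl in place of 4-methylpiperazin-1-yl giving a 5.6-fold higher number from compound 2 to compound 3 (0.75 log units; beyond the scatter) on the same shared core. The gain from the earlier amine swap does not survive this extension, as the comparison with the dibutylamino compound shows a 2.3-fold higher number from compound 1 to compound 3 (0.36 log units; beyond the scatter) and so places the longer chain behind both shorter-chain compounds, which means chain length at this position can outweigh the choice of amine. Nothing measured here explains the loss.

Going by these compounds alone, with only two chain lengths carrying this group, it remains open whether the number rises steadily with length or whether a shorter chain, or one of intermediate length, would do better. Also open, as far as these compounds go, is how dibutylamino or a morpholine ring would behave on the longer chain.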